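A few compounds are considered here, and "the series" means these few. Any claim that something is new, unique, unknown or untested is made for them only; others in the source may bear on it.

- Compound 1 `Cc1cc(N2CC[C@@H](C)[C@@H](N(C)c3ncnc4[nH]ccc34)C2)n2nc(SCc3ccccc3Br)nc2n1`: 21300 nM
- Compound 2 `Cc1cc(N2CC[C@@H](C)[C@@H](N(C)c3ncnc4[nH]ccc34)C2)n2nc(SCc3ccc(F)cc3)nc2n1`: 26000 nM
- Compound 3 `CCc1cc(N2CC[C@@H](C)[C@@H](N(C)c3ncnc4[nH]ccc34)C2)n2ncnc2n1`: > 100000 nM

These results all come from a functional assay on HGC-27 cells (Homo sapiens) for inhibition, read by MTT assay, with a stated time of 72 h; a higher number here means a weaker inhibitor, a lower number a stronger inhibitor. The entry for compound 3 is a limit, not a number. Compound 2 stands within the scatter of compound 1, and no other true number is available for comparison.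

Compound 4 `COc1ccc(CSc2nc3nc(C)cc(N4CC[C@@H](C)[C@@H](N(C)c5ncnc6[nH]ccc56)C4)n3n2)cc1` has methoxy in place of fluoro on an aromatic carbon, para to a large group (methoxy in place of fluoro on an aromatic carbon). Among the measured compounds shown here, the only measured step bearing on this change swaps 2-bromophenyl for 4-fluorophenyl, and it is a 1.2-fold higher number from compound 1 to compound 2 (0.09 log units; within the scatter). No step beyond the scatter is therefore expected in this assay. The expected step is a 1.1-fold lower number from compound 2 to compound 4 (0.03 log units; within the scatter). For compound 4 the estimated value is 24000 nM, with an expected range from 11000 nM to 55000 nM.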

Compound 4, half-maximal inhibitory concentration: 18200 nM
For compound 4 the middle estimate is 1.3-fold (0.12 log units) above the measured one, and the stated range covers the measured number.
By their numbers in this assay, from the lowest: compounds 4, 1 and 2 (each within the scatter of the next). At a limit, above all of these: compound 3.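

In this assay, methoxy in place of fluoro on an aromatic carbon, para to a large group, gives a 1.4-fold lower number from compound 2 to compound 4 (0.15 log units; within the scatter), and 4-methoxyphenyl in place of 2-bromophenyl gives a 1.2-fold lower number from compound 1 to compound 4 (0.07 log units; within the scatter). So a substituent that brings a hydrogen-bond acceptor to this position, as methoxy does, still leaves the number within the scatter of both earlier aryl compounds. Nothing in the data at hand bears on why these numbers stay so close.

On these data alone, whether an amine or a carboxylic acid at this position would move the number beyond the scatter stays open. So does the effect of a longer chain between the sulfur and the ring.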